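Nitro for methyl on a benzyl arm: expected cytotoxicity

A few compounds are considered here, and "the series" means these few. Any claim that something is new, unique, unknown or untested is made for them only; others in the source may bear on it.

Compound 1, `Cc1cccc(Cn2cc(CO)c3ccccc32)c1`, in an ADME assay on T29 cells (Homo sapiens) for cytotoxicity, read by sulforhodamine B assay, with a stated time of 3 days (on this read-out higher numbers stand for weaker inhibition and lower numbers for stronger inhibition), gives > 31600 nM, which is a limit of the assay and not a number.
Compound 2, `Cc1ccc(Cn2cc(CO)c3ccccc32)cc1`, in this assay gives > 31600 nM, again a limit of the assay.
Compound 3, `O=[N+]([O-])c1cccc(Cn2cc(CO)c3ccccc32)c1`, in this assay gives > 31600 nM, also a limit of the assay.

All three measured compounds share a core, and the difference between the cores of compound 1 and compound 2 is not broken down here. From compound 1 to compound 3 the change is nitro in place of methyl on an aromatic carbon, and the step it made is a step that the two limits leave unreadable from compound 1 to compound 3. The same kind of change is made from compound 2 to compound 4, `O=[N+]([O-])c1ccc(Cn2cc(CO)c3ccccc32)cc1`, which has not yet been measured: nitro in place of methyl on an aromatic carbon. The two changes are not identical in their surroundings, since in compound 3 the nitro sits meta to a large group, whereas in compound 4 it sits para to a large group.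

Among the compounds with values here, compound 4 is expected to remain at the limit of this assay, because of the limit of > 31600 nM in this assay, at which 3 of the 3 values shown sit, so that no measured compound so far gives a number below it. The step from compound 2 to compound 4 is therefore estimated to be a step that the limit leaves unreadable from compound 2 to compound 4, with the understanding that a value at the limit of this assay gives no readable size. Compound 4 is expected to give about 60000 nM, between 31600 nM and 150000 nM.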

Compound 4, half-maximal inhibitory concentration: > 31600 nM
Compound 4: only a limit was reported; the forecaster's own chance of this, stated with the estimate: 85%; the middle value is on the limit's open side.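

Compound 2 and compound 4 both end at a limit of this assay and not at a number, so the step between them, nitro in place of methyl, cannot be read. The compounds shown leave open how strongly any of them acts on these cells, and whether either change matters at all, since every result sits at the same limit: the limit of > 31600 nM in this assay, at which 4 of the 4 values shown sit.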